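The compounds below may be only part of what the source reports. "The series", "measured", "known", "first", "only" and "open" are said of these compounds alone.

Measured so far in a functional assay on HEK293 cells for agonist activity at Bombesin receptor subtype-3 (Mus musculus), read by luminescence and calcium flux, with a stated time of 10 min; on this read-out lower numbers stand for an effect already at smaller amounts and higher numbers for an effect only at larger amounts of compound: compound 1 `CCC(C)(C)Cc1c[nH]c(CCc2ccc(-c3cccc(C)n3)cc2)n1` gives 19 nM; compound 2 `CCC(C)(C)Cc1c[nH]c(CCc2ccc(-n3ncnn3)cc2)n1` gives 25 nM; compound 3 `CCC(C)(C)Cc1c[nH]c(CCc2ccc(-c3cccc(C#N)n3)cc2)n1` gives 26 nM.

Compound 3 holds the highest of the three numbers, yet all three sit within the scatter of one another: a 1.4-fold higher number from compound 1 to compound 3 (0.14 log units; within the scatter) and a 1.0-fold higher number from compound 2 to compound 3 (0.02 log units; within the scatter). Compound 4 `CCC(C)(C)Cc1c[nH]c(CCc2ccc(-c3csnn3)cc2)n1` differs from compound 3 by 1,2,3-thiadiazol-4-yl in place of 6-cyanopyridin-2-yl on an aromatic carbon. Going by the values given here, the closest precedent is a 1.3-fold higher number from compound 1 to compound 2 (0.12 log units; within the scatter), where 6-methylpyridin-2-yl gave way to 2H-tetrazol-2-yl, a five-membered heteroaryl, without a shift beyond the scatter; a 1.0-fold higher number from compound 2 to compound 3 (0.02 log units; within the scatter) was likewise flat. For the five-membered 1,2,3-thiadiazol-4-yl in this position the expectation is therefore no step beyond the scatter, a 1.1-fold higher number from compound 3 to compound 4 (0.03 log units; within the scatter). Compound 4 is estimated at 28 nM (range 12 nM to 70 nM).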

Compound 4, half-maximal effective concentration: 11 nM
Compound 4: the middle estimate sits 2.5-fold (0.41 log units) above what was measured; the whole stated range lies above it.
By their numbers in this assay, from the lowest: compounds 4, 1, 2 and 3 (each within the scatter of the next, the first and the last beyond it).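

Going by these compounds alone, this position is not as flat as the earlier compounds suggested: 1,2,3-thiadiazol-4-yl gives the first steps beyond the scatter, though modest ones (a 2.4-fold lower number from compound 3 to compound 4 (0.37 log units; beyond the scatter); a 2.3-fold lower number from compound 2 to compound 4 (0.36 log units; beyond the scatter)). Against 6-methylpyridin-2-yl the same group stays within the scatter (a 1.7-fold lower number from compound 1 to compound 4 (0.24 log units; within the scatter)), so compound 4 does not separate from compound 1. Nothing measured here explains the steps. Open, as far as these compounds go, is whether a carboxylic acid or an amine at this position keeps the number at this level. Also open, from the compounds shown here alone, is whether the steps hold with a shorter chain on the shared core.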